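Swapping the aryl amide: 3-hydroxyphenyl to 2-fluorophenyl

A few compounds are considered here, and "the series" means these few. Any claim that something is new, unique, unknown or untested is made for them only; others in the source may bear on it.

Compound 1 `Cc1ccc(S(=O)(=O)N[C@@H](CC(=O)NC(C)(C)C)C(=O)NCCNC(=O)c2cc(Cl)ccn2)cc1` gives > 11100 nM in an ADME assay on Karpas-1106P cells (Homo sapiens) for cytotoxicity; a higher number here means that more compound is needed for the effect, a lower number that less compound is needed; this is a limit of the assay, not a number.
Compound 2 `Cc1ccc(S(=O)(=O)N[C@@H](CC(=O)NC(C)(C)C)C(=O)NCCNC(=O)c2cccc(O)c2)cc1` gives > 11100 nM in this assay; this too is a limit.

Compound 2 therefore stands only at a limit in this assay. The step that the two limits leave unreadable from compound 1 to compound 2 cannot be read because of the limit of > 11100 nM in this assay, at which 2 of the 2 values shown sit. Compound 3 `Cc1ccc(S(=O)(=O)N[C@@H](CC(=O)NC(C)(C)C)C(=O)NCCNC(=O)c2ccccc2F)cc1` carries the change (2-fluorophenyl in place of 3-hydroxyphenyl on a carbonyl carbon). Among the compounds with values here, the one measured step that bears on it is unreadable, so no direction or size can be drawn. Compound 3 is expected at 15000 nM, between 8000 nM and 40000 nM. The expected step that the limit leaves unreadable from compound 2 to compound 3 is estimated to stay unreadable.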

Compound 3, half-maximal effective concentration: > 11100 nM
Compound 3 ended at the assay's limit; the forecaster's own chance of this, stated with the estimate: 85%; the middle value is on the limit's open side.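

Compound 3 also ends at a limit, so no step among compound 1, compound 2 and compound 3 can be read: the limit of > 11100 nM in this assay, at which 3 of the 3 values shown sit.

In this assay the compounds shown leave open how much of each is actually needed for the effect, and whether changing the aryl group matters at all.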